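Swapping Ethyl for Chloro on the Benzyl Ring

The source may hold more compounds than are shown below. What is called first, only, known or untested is meant among the compounds shown, and "the series" means these compounds.

Compound 1 `O=C(O)CCCSCCN1C(=O)OC[C@@H]1/C=C/[C@@H](O)Cc1ccccc1` gives in an assay on CHO cells for displacement of a labelled ligand from prostaglandin E2 receptor EP1 subtype (Mus musculus), read by scintillation counting, with a stated time of 20 min (on this read-out lower numbers stand for stronger inhibition and higher numbers for weaker inhibition), only a limit, > 10000 nM.
Compound 2 `CCc1cccc(C[C@H](O)/C=C/[C@H]2COC(=O)N2CCSCCCC(=O)O)c1` gives in this assay 2400 nM.

Compound 2 holds the only definite number shown; the other value is a limit. The step of an at least 4.1-fold lower number from compound 1 to compound 2 (0.61 log units; beyond the scatter) came with ethyl in place of hydrogen on an aromatic carbon, and its size is bounded by the limit of > 10000 nM in this assay, at which 1 of the 2 values shown sits. Compound 3 `O=C(O)CCCSCCN1C(=O)OC[C@@H]1/C=C/[C@@H](O)Cc1cccc(Cl)c1` differs from compound 2 by chloro in place of ethyl on an aromatic carbon. Within the data shown here, no measured step compares chloro with ethyl, so the only guide is that a substituent on that aromatic carbon remains. The expected step is a 1.2-fold lower number from compound 2 to compound 3 (0.08 log units; within the scatter), within the scatter. Compound 3 is estimated at 2000 nM, between 600 nM and 7000 nM.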

Compound 3, inhibition constant: > 10000 nM
Compound 3: only a limit was reported; the forecaster's own chance of this, stated with the estimate: 15%; middle value at least 5.0-fold (0.69 log units) from the limit.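

Chloro in place of ethyl on this aromatic carbon brings an at least 4.1-fold higher number from compound 2 to compound 3 (0.61 log units; beyond the scatter), so having any substituent there is not enough and the identity of the group matters. Of the two groups shown at this place, only ethyl gives a definite number in this assay, with compound 2 at 2400 nM. The step between the unsubstituted compound 1 and the chloro compound 3 cannot be read, since both values are limits: the limit of > 10000 nM in this assay, at which 2 of the 3 values shown sit.

From the compounds shown here alone, whether a propyl or a methoxy group at this place would match ethyl remains open.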